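Working notes: quinolin-5-yl in place of 2-methylpyridin-3-yl

The compounds below may be only part of what the source reports. "The series", "measured", "known", "first", "only" and "open" are said of these compounds alone.

Measured in a physicochemical assay for solubility, in phosphate buffer, at pH 7.4; on this read-out higher numbers stand for higher solubility and lower numbers for lower solubility:
Compound 1 `NC(=O)C1CCN(c2nccnc2OC2CN(c3ccc4ccccc4n3)C2)CC1`: 14000 nM
Compound 2 `Cc1ncccc1-c1nccnc1OC1CN(c2ccc3ccccc3n2)C1`: 253000 nM

Among the compounds with values here, compound 2 holds the higher of the two numbers so far, well clear of compound 1. The next compound, compound 3 `c1ccc2nc(N3CC(Oc4nccnc4-c4cccc5ncccc45)C3)ccc2c1`, carries quinolin-5-yl in place of 2-methylpyridin-3-yl on an aromatic carbon. The site is the one that already changed between the two measured compounds.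

Within the data shown here, only one measured step bears on this: an 18-fold higher number from compound 1 to compound 2 (1.26 log units; beyond the scatter). It is large, so this site can clearly shift the number in this assay. However, that step involves a different pair of groups, and no measured compound carries quinolin-5-yl, so the direction is a judgement rather than a trend. Among the measured compounds shown here, with compound 2 at 253000 nM, the top of the range so far, a fall beyond the scatter is expected, somewhat smaller than the one measured step. The expected change is a 7.2-fold lower number from compound 2 to compound 3 (0.86 log units; beyond the scatter). For compound 3 the estimate is 35000 nM, with an expected range of 7000 nM to 150000 nM.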

Compound 3, solubility: 47000 nM
Estimate against measurement, compound 3: 1.3-fold (0.13 log units) below; measured number inside the range.
By their numbers in this assay, from the lowest: compound 1; then compound 3; then compound 2.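

In this assay this site responds even to an exchange between two aromatic groups: quinolin-5-yl in place of 2-methylpyridin-3-yl gives a 5.4-fold lower number from compound 2 to compound 3 (0.73 log units; beyond the scatter) while the count of hydrogen-bond donors and acceptors and the absence of net charge stay the same. Compound 3 still stands clear of the carbamoylpiperidine compound, with a 3.4-fold higher number from compound 1 to compound 3 (0.53 log units; beyond the scatter) as the step, so among these three compounds both aromatic groups give higher numbers than 4-carbamoylpiperidin-1-yl, and no compound shown goes against this, although the two aromatic groups are themselves well apart. No supporting measurement is available to account for the order of the three compounds.

Compound 2 and compound 3 differ both in the methyl group and in the added six-membered aromatic ring of carbon only, so the contribution of each remains unresolved, and an unsubstituted pyridin-3-yl would be needed to separate them. How a carboxylic acid, a primary amine or a morpholine at this site would compare with the three groups shown also remains open.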